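The source may report more compounds than this note shows. Statements on the series, on what has been measured and on what is new or still open speak of the compounds shown alone.

Measured compounds:
Compound 1, `COc1cc(-c2cc(/C=C/C(=O)c3ccc(Cl)c(Cl)c3)[nH]n2)cc(OC)c1OC`: in a functional assay on Malme-3M cells (Homo sapiens) for cytotoxicity, read by sulforhodamine B assay, with a stated time of 48 h, tested at 10 uM (a lower number here means a stronger effect, a higher number a weaker effect of the compound at the concentration tested), compound 1 gives 72%.
Compound 2, `COc1ccc(-c2cc(/C=C/C(=O)c3ccc(N)cc3)[nH]n2)cc1`: in this assay compound 2 gives -23%.

Of the two numbers recorded in this assay, compound 1 holds the higher one, which means the weaker effect at the concentration tested; compound 2 sits far below it, and the gap between the two is well beyond the usual scatter. The two compounds differ in more than one place, so their readings show only where each stands, not what any single group contributes.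

Compound 3, `COc1ccc(C(=O)/C=C/c2cc(-c3cc(OC)c(OC)c(OC)c3)n[nH]2)cc1OC`, has not yet been measured in this assay. It differs from compound 1 in a single place: 3,4-dimethoxyphenyl in place of 3,4-dichlorophenyl on a carbonyl carbon. Within the data shown here, no measured pair shows this exact exchange, so there is no recorded step to lean on. Within that limit, a modest move toward a lower reading is expected for compound 3, and the step of a number 12 percentage points lower from compound 1 to compound 3 (beyond the scatter) is estimated to lie close to the edge of the scatter rather than far beyond it. The reading for compound 3 in this assay is therefore expected near 60%, within a range from 25% to 90%.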

Compound 3, a percentage reported as activity, at one concentration (the size of the read-out at that concentration, not a potency): -82%
The estimate for compound 3 lay 142 percentage points above the measured number; the measured number lies below the stated range.
By their numbers in this assay, from the lowest: compound 3; then compound 2; then compound 1.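

Among these compounds, the exchange of 3,4-dichlorophenyl for 3,4-dimethoxyphenyl on a carbonyl carbon, with the rest of the structure unchanged, gives in this assay the first readable step (a number 154 percentage points lower from compound 1 to compound 3 (beyond the scatter)), so this position alone can govern the reading at the concentration tested. The earlier compounds shown here differed in more than one place and could not isolate any single site, whereas this pair ties a large change to one aryl group on the carbonyl and carries the reading from the positive side of zero, where compound 1 gives 72%, to the negative side, where compound 3 gives -82%. Nothing available explains why this exchange has so large an effect, and no measurement bears on a cause.

A single pair cannot separate the loss of the two chlorine atoms from the gain of the two methoxy groups. A plain phenyl, a 3,4-dimethylphenyl or a 3,4-dihydroxyphenyl at this place would be needed to divide the two. Going by these compounds, it also remains open whether a step of this size would recur on a core carrying something other than the 3,4,5-trimethoxyphenyl group shared by this pair.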